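Replacing fluoro with chloro on the N-aryl ring

The source may report more compounds than this note shows. Statements on the series, on what has been measured and on what is new or still open speak of the compounds shown alone.

Of the compounds shown here, three sharing one core have been measured in a functional assay on MKN-45 cells (Homo sapiens) for cytotoxicity, read by MTT assay, with a stated time of 72 h; a higher number here means a weaker inhibitor, a lower number a stronger inhibitor. Compound 1 `COc1ccc(-n2nc(C(=O)Nc3ccc(Oc4ccncc4-c4cccnc4)c(F)c3)c3ccccc3c2=O)cc1` gives 740 nM, compound 2 `O=C(Nc1ccc(Oc2ccncc2-c2cccnc2)c(F)c1)c1nn(-c2ccccc2)c(=O)c2ccccc12` gives 90 nM, and compound 3 `O=C(Nc1ccc(Oc2ccncc2-c2cccnc2)c(F)c1)c1nn(-c2ccc(F)cc2)c(=O)c2ccccc12` gives 320 nM. Compound 3 therefore holds the second highest number of the three; it sits nearest to compound 1 and furthest from compound 2, and the steps of a 2.3-fold lower number from compound 1 to compound 3 (0.36 log units; beyond the scatter) and a 3.6-fold higher number from compound 2 to compound 3 (0.55 log units; beyond the scatter) both lie beyond the scatter.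

Compound 4 `O=C(Nc1ccc(Oc2ccncc2-c2cccnc2)c(F)c1)c1nn(-c2ccc(Cl)cc2)c(=O)c2ccccc12` differs from compound 3 in one place: chloro in place of fluoro on an aromatic carbon. Within the data shown here, the steps that bear on this change all alter the same aromatic carbon: an 8.2-fold lower number from compound 1 to compound 2 (0.91 log units; beyond the scatter), a 2.3-fold lower number from compound 1 to compound 3 (0.36 log units; beyond the scatter) and a 3.6-fold higher number from compound 2 to compound 3 (0.55 log units; beyond the scatter). Across these, hydrogen gave the lowest number, fluoro a higher one, and methoxy the highest, so every group put onto that carbon so far has raised the number in this assay relative to hydrogen. Among the measured compounds shown here, no measured step speaks directly to chloro, so the expectation rests on this small series alone.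

Compound 4 is expected to land close to compound 3, with the step of a 1.3-fold higher number from compound 3 to compound 4 (0.10 log units; within the scatter) estimated as modest and most likely upward. The estimate for compound 4 in this assay is 400 nM, expected to fall between 150 nM and 1100 nM.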

Compound 4, half-maximal inhibitory concentration: 430 nM
For compound 4 the middle estimate is 1.1-fold (0.03 log units) below the measured one; the range from low to high includes it.
By their numbers in this assay, from the lowest: compound 2; then compounds 3, 4 and 1 (each within the scatter of the next, the first and the last beyond it).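

In this assay, the change from 4-fluorophenyl to 4-chlorophenyl gives a 1.3-fold higher number from compound 3 to compound 4 (0.13 log units; within the scatter), so these two halogens cannot be told apart at this position, and chloro also stays close to methoxy, with a 1.7-fold lower number from compound 1 to compound 4 (0.24 log units; within the scatter), even though compounds 1 and 3 are separated beyond the scatter. Chloro is now the third group on this aromatic carbon to give a number clearly above that of hydrogen, with a 4.8-fold higher number from compound 2 to compound 4 (0.68 log units; beyond the scatter), which leaves compound 2 as the strongest of the four and no compound against the pattern that every group placed here so far raises the number. Nothing shown here offers a measured reason for this pattern.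

The compounds shown leave open whether any group on this carbon could match or improve on hydrogen, such as an amine, a carboxylic acid or a hydroxyl group. They also leave open whether chloro or fluoro would behave the same way on another carbon of this ring, away from the position para to the large group.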